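The compounds below may be only part of what the source reports. "The series", "measured", "known", "first", "only" and "open" are said of these compounds alone.

Values in a functional assay on HepG2 cells (Homo sapiens) for antiproliferative activity, read by MTT assay, with a stated time of 48 h; on this read-out lower numbers stand for stronger inhibition and higher numbers for weaker inhibition:
- Compound 1 `COc1ccc(CN2C(=O)C(=O)c3cc(-c4ccc(F)cc4)ccc32)cc1`: 3150 nM
- Compound 2 `COc1ccc(CN2C(=O)C(=O)c3cc(-c4ccc(C)cc4)ccc32)cc1`: > 10000 nM, a limit
- Compound 3 `COc1ccc(CN2C(=O)C(=O)c3cc(-c4ccc(OC(C)C)cc4)ccc32)cc1`: > 10000 nM, a limit

Compound 3 has no number, and its > 10000 nM is only a limit of the assay. The same holds for compound 2, so the series shows (the limit of > 10000 nM in this assay, at which 2 of the 3 values shown sit).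

The next compound is compound 4 `COc1ccc(CN2C(=O)C(=O)c3cc(-c4ccc(C(F)(F)F)cc4)ccc32)cc1`. The change is trifluoromethyl in place of isopropoxy on an aromatic carbon, para to a large group.

Going by the values given here, no measured step covers this exchange directly. The nearest evidence is an at least 3.1-fold higher number from compound 1 to compound 2 (0.50 log units; beyond the scatter) and an at least 3.1-fold higher number from compound 1 to compound 3 (0.50 log units; beyond the scatter), both beyond the scatter, while a step that the two limits leave unreadable from compound 2 to compound 3 gives no usable size. Of the three compounds, only compound 1, with its fluoro group, reaches a number, at 3150 nM. Compound 4 also carries fluorine, but on a group of a different size, so this is weak support for an expected move toward compound 1. The expected result is a modest shift to a lower number in this assay, and a second reading at the limit remains about as likely. The expected step is an at least 1.4-fold lower number from compound 3 to compound 4 (0.15 log units; that floor lies within the scatter). For compound 4 the estimated value is 7000 nM, with an expected range from 2500 nM to 15000 nM.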

Compound 4, half-maximal inhibitory concentration: 820 nM
Compound 4: middle estimate off by 8.5-fold (0.93 log units), on the high side, and the stated range ends above it.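

Until now only the fluoro compound gave a number in this assay, and trifluoromethyl on this aromatic carbon, para to a large group, goes beyond it, with a 3.8-fold lower number from compound 1 to compound 4 (0.58 log units; beyond the scatter). Against the two compounds without a number the gain is large, with an at least 12-fold lower number from compound 2 to compound 4 (1.08 log units; beyond the scatter) and an at least 12-fold lower number from compound 3 to compound 4 (1.08 log units; beyond the scatter), so a single exchange at this position separates a measurable value from none. Among these four compounds, fluoro and trifluoromethyl give numbers while methyl and isopropoxy do not, and no compound goes against this split, although two of the four readings carry no number: the limit of > 10000 nM in this assay, at which 2 of the 4 values shown sit.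

The compounds shown leave open whether this split holds for other groups on the same carbon, such as chloro, a nitrile, an amine or a carboxylic acid, and whether fluorine matters at all or only these two particular groups. They also leave open whether the gain from trifluoromethyl survives a change to the methoxy group at the other end of the molecule, which stays the same throughout this set.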